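The source may hold more compounds than are shown below. What is called first, only, known or untested is meant among the compounds shown, and "the series" means these compounds.

Measured so far:
- compound 1, `CN1CCC[C@H]1COc1cccc(C#CCCCCO)c1`: 8300 nM
- compound 2, `CN1CCC[C@H]1COc1cc(O)cc(-c2ccc(O)cc2)c1`: 30 nM

Both numbers come from an assay on HEK243 cells for displacement of a labelled ligand from Neuronal acetylcholine receptor; alpha3/beta4 (Homo sapiens), read by scintillation counting, with a stated time of 5 min; a higher number here means a weaker inhibitor, a lower number a stronger inhibitor. Among the measured compounds shown here, compound 1 stands at the highest of the two values shown, and compound 2 is its only neighbour: in this assay compound 2 gives 30 nM, far lower than compound 1 and well beyond the usual scatter of repeated measurements. The two structures differ in more than one place, so the gap between them cannot be assigned to any single change.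

Compound 3, `CN1CCC[C@H]1COc1cc(C#CCCCCO)cc([N+](=O)[O-])c1`, has not yet been measured. It differs from compound 1 in exactly one place: nitro in place of hydrogen on an aromatic carbon. For the measured compounds named here, no pair of measured compounds shows what this exchange does in this assay, so nothing here points firmly in either direction. Going by the values given here, with no such pair to lean on, the expected step is a 1.2-fold lower number from compound 1 to compound 3 (0.07 log units; within the scatter), which would keep compound 3 within the scatter of compound 1. On that basis compound 3 is estimated at 7000 nM, with a range from 2000 nM to 25000 nM.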

Compound 3, inhibition constant: 1200 nM
Beside the measured number, compound 3's estimate is 5.8-fold (0.77 log units) above it; measured number below the stated range.
By their numbers in this assay, from the lowest: compound 2; then compound 3; then compound 1.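

In this assay, among the compounds shown here, placing a nitro group on the aromatic carbon meta to both the (1-methylpyrrolidin-2-yl)methoxy group and the 6-hydroxyhex-1-yn-1-yl group gives a 6.9-fold lower number from compound 1 to compound 3 (0.84 log units; beyond the scatter) and provides the first comparison here in which only one place in the structure changes. It shows that this carbon matters for the measured number, since replacing its hydrogen moves the result by more than ordinary repeat-to-repeat variation, and the direction of that move is towards a stronger inhibitor. No separate measurement here bears on this gain.

A single exchange at a single position leaves open whether the gain belongs to the nitro group in particular or whether other groups at this carbon, such as an amine, a carboxylic acid, a methoxy group or a chlorine atom, would shift the number in the same direction or the opposite one. It also leaves open whether the same gain would appear with a different chain in place of the 6-hydroxyhex-1-yn-1-yl group, such as a longer or shorter one, since only this chain is shown alongside the exchange.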